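The compounds below may be only part of what the source reports. "The series", "measured", "known", "first", "only" and "open" are said of these compounds alone.

Compound 3 `CO[C@@H]1CC=C2NN(c3cc4ccccc4[nH]3)C(=O)C[C@]2(c2ccccc2)O1` is one of three compounds of the shared core read in a functional assay on SK-BR-3 cells (Homo sapiens) for inhibition, read by sulforhodamine B assay, with a stated time of 48 h; a higher number here means a weaker inhibitor, a lower number a stronger inhibitor. In this assay compound 3 gives 530 nM, the second highest number of the three. Compound 1 `CO[C@@H]1CC=C2NN(c3cc4ccccc4[nH]3)C(=O)C[C@]2(c2ccncc2)O1` gives 150 nM, and the step of a 3.5-fold higher number from compound 1 to compound 3 (0.55 log units; beyond the scatter) arises from phenyl in place of pyridin-4-yl on a saturated ring carbon. Compound 2 `CO[C@@H]1CC=C2NN(c3cncnc3)C(=O)C[C@]2(c2ccccc2)O1` gives 5300 nM, and the step of a 10-fold lower number from compound 2 to compound 3 (1.00 log units; beyond the scatter) arises from 1H-indol-2-yl in place of pyrimidin-5-yl on an amide-type nitrogen in a ring.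

Compound 4 `CO[C@@H]1CC=C2NN(c3cc(F)cc(Cl)c3)C(=O)C[C@]2(c2ccccc2)O1` differs from compound 3 at that same nitrogen: 3-chloro-5-fluorophenyl in place of 1H-indol-2-yl on an amide-type nitrogen in a ring. Among the compounds with values here, only the step from compound 2 to compound 3 bears on this change, since it alters the same position; there, 1H-indol-2-yl in place of pyrimidin-5-yl gave a 10-fold lower number from compound 2 to compound 3 (1.00 log units; beyond the scatter). Compound 4 carries neither of those groups but a six-membered aromatic ring of carbon only bearing chlorine and fluorine, so a number between those of compound 2 and compound 3 is the most that can be read from the set, leaning towards a higher number than compound 3. An increase in this assay is therefore expected for compound 4, as a 2.8-fold higher number from compound 3 to compound 4 (0.45 log units; beyond the scatter). For compound 4 the expected value in this assay is 1500 nM, within a range from 400 nM to 6000 nM.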

Compound 4, half-maximal inhibitory concentration: 17600 nM
Compound 4: middle estimate off by 12-fold (1.07 log units), on the low side; measured number above the stated range.
By their numbers in this assay, from the lowest: compound 1; then compound 3; then compound 2; then compound 4.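

In this assay, within the data shown here, the group on the amide-type nitrogen in a ring moves the number further than the earlier compounds showed: 3-chloro-5-fluorophenyl in place of 1H-indol-2-yl gives a 33-fold higher number from compound 3 to compound 4 (1.52 log units; beyond the scatter) on the same shared core, and 3-chloro-5-fluorophenyl in place of pyrimidin-5-yl gives a 3.3-fold higher number from compound 2 to compound 4 (0.52 log units; beyond the scatter) as the second step. Compound 4 therefore falls outside the span set by compound 2 and compound 3 rather than inside it, so a six-membered aromatic ring of carbon only bearing these two halogens ranks last of the three groups at this nitrogen, and the 1H-indol-2-yl, with its one five-membered and one six-membered aromatic ring, ranks first. No measurement is at hand that accounts for either step.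

As far as these compounds go, it remains open whether a plain phenyl, a 3-chlorophenyl or a 3-fluorophenyl at this nitrogen would read closer to compound 4 or to compound 2, which would separate the part played by each halogen from that of the ring itself. Also open, from the compounds shown here alone, is whether pyridin-4-yl on the saturated ring carbon would shift the number in the same direction with 3-chloro-5-fluorophenyl on the nitrogen as it does with 1H-indol-2-yl there.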